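The compounds below may be only part of what the source reports. "The series", "measured", "known", "first", "only" and "open" are said of these compounds alone.

Of the compounds shown here, three have so far been measured in an assay on brain for binding affinity to Neuronal acetylcholine receptor; alpha4/beta2 (Homo sapiens); a lower number here means a stronger inhibitor, a higher number a weaker inhibitor. Compound 2 `c1cncc(CN2CCCC2)c1` gives 30 nM and compound 3 `CNCCC#Cc1ccc(Cl)nc1` gives 154 nM, both as numbers. Compound 1 `C(#Cc1cccnc1)CCN1CCCC1` gives only a limit in this assay, > 10000 nM, and so its true place on the scale is not known; it sits at the limit of > 10000 nM in this assay, at which 1 of the 3 values shown sits. For the measured compounds named here, no two of these three differ in one place, so no measured step is available to lean on. Compound 4 `C[N+](C)(C)CCC#Cc1cccnc1` differs from compound 1 in one place: a group of 4 heavy atoms (3 carbon, 1 nitrogen; no ring) in place of a group of 5 heavy atoms (4 carbon, 1 nitrogen; one five-membered non-aromatic ring with 1 hetero atom), on a saturated chain carbon, two bonds along the chain from a triple-bonded carbon. Since compound 1 stands at a limit, compound 4 is expected to stay near that limit or to gain only modestly, a step of an at least 1.2-fold lower number from compound 1 to compound 4 (0.09 log units; that floor lies within the scatter). Compound 4 is accordingly estimated at 8000 nM, within 1500 nM to 30000 nM.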

Compound 4, inhibition constant: 470 nM
Compound 4: middle estimate off by 17-fold (1.23 log units), on the high side; the measured number lies below the stated range.
By their numbers in this assay, from the lowest: compound 2; then compound 3; then compound 4. At a limit, above all of these: compound 1.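

In this assay, putting the ring-free group of net charge +1 in place of pyrrolidin-1-yl on this saturated chain carbon gives an at least 21-fold lower number from compound 1 to compound 4 (1.32 log units; beyond the scatter). The group at this place can therefore move the number strongly, which no earlier comparison could show. Compound 1 stands at a limit of the assay, so the true size of this step is not known, because only a floor can be read: the limit of > 10000 nM in this assay, at which 1 of the 4 values shown sits.

The compounds shown do not separate the loss of the ring from the gain of charge. A dimethylamino group, or a pyrrolidine ring with a methyl group on its nitrogen, at this place would bear on that question.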